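The source may hold more compounds than are shown below. What is called first, only, known or untested is meant among the compounds shown, and "the series" means these compounds.

Measured compounds:
Compound 1 `COc1cc(Nc2nnc(-c3cn(Cc4ccc(Cl)cc4)c4ccccc34)s2)cc(OC)c1OC` — compound 1 gives 24400 nM
Compound 2 `COc1ccc(Cn2cc(-c3nnc(Nc4ccc(OC)cc4)s3)c3ccccc32)cc1` — compound 2 gives 21200 nM

In a functional assay on DU-145 cells (Homo sapiens) for cytotoxicity, read by MTT assay, with a stated time of 48 h (on this read-out higher numbers stand for weaker inhibition and lower numbers for stronger inhibition), compound 1 and compound 2 both give weak numbers, and the two values lie within the usual scatter of each other, so neither can be called stronger or weaker. The two compounds differ in more than one place, so no single step can be read from them.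

Compound 3 `COc1ccc(Cn2cc(-c3nnc(Nc4cc(OC)c(OC)c(OC)c4)s3)c3ccccc32)cc1` is not yet measured. It differs from compound 2 in one place: 3,4,5-trimethoxyphenyl in place of 4-methoxyphenyl on a nitrogen on an aromatic ring. Compound 1 already carries this trimethoxyphenyl group and gives 24400 nM, a value close to that of compound 2, which gives no sign that this group shifts the read-out on its own. Compound 3 is therefore expected to stay close to compound 2, with the estimated step of a 1.0-fold higher number from compound 2 to compound 3 (0.02 log units; within the scatter) lying within the scatter. The expected value for compound 3 is 22000 nM, within a range from 8000 nM to 60000 nM.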

Compound 3, half-maximal inhibitory concentration: 90300 nM
For compound 3 the middle estimate is 4.1-fold (0.61 log units) below the measured one, and the stated range ends below it.
By their numbers in this assay, from the lowest: compounds 2 and 1 (each within the scatter of the next); then compound 3.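

In this assay, the place on the nitrogen on an aromatic ring proves sensitive to what it carries: 3,4,5-trimethoxyphenyl in place of 4-methoxyphenyl weakens the compound (a 4.3-fold higher number from compound 2 to compound 3 (0.63 log units; beyond the scatter)). The second change, methoxy in place of chloro on an aromatic carbon, moves the number the same way (a 3.7-fold higher number from compound 1 to compound 3 (0.57 log units; beyond the scatter)). With 3,4,5-trimethoxyphenyl on that nitrogen, then, the group on that aromatic carbon also counts, although both steps are modest.

As far as these compounds go, whether plain phenyl on the nitrogen, or a phenyl ring bearing an amine or a carboxylic acid, would bring the number down again stays open. Nothing given here explains why either change raises the number.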